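From dimethoxyphenyl to plain phenyl in a growth inhibitor

The source may report more compounds than this note shows. Statements on the series, on what has been measured and on what is new or still open speak of the compounds shown alone.

In a functional assay on A2780 cells (Homo sapiens) for inhibition, read by sulforhodamine B assay (a higher number here means a weaker inhibitor of growth, a lower number a stronger inhibitor of growth), compound 3 `COc1ccc(-c2ccc(-c3ccc(-c4nc5cc(C)ccc5[nH]4)cc3)cc2)cc1OC` gives 2130 nM. Compound 2 `Cc1ccc2[nH]c(-c3ccc(-c4ccc(-c5ccc(N(C)C)cc5)cc4)cc3)nc2c1` sits level with it at 2210 nM, while compound 1 `c1ccc(-c2ccc(-c3ccc(-c4nc5ccccc5[nH]4)cc3)cc2)cc1` stands much higher at 32100 nM. Compound 3 therefore has the lowest number of the three, though it cannot be separated from compound 2.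

The next compound, compound 4 `Cc1ccc2[nH]c(-c3ccc(-c4ccc(-c5ccccc5)cc4)cc3)nc2c1`, keeps the shared core of compound 3 and changes one group: phenyl in place of 3,4-dimethoxyphenyl on an aromatic carbon, para to a large group (phenyl in place of 3,4-dimethoxyphenyl on an aromatic carbon).

Within the data shown here, only one measured step offers direct guidance: a 1.0-fold lower number from compound 2 to compound 3 (0.02 log units; within the scatter). It exchanges one substituted phenyl for another, so it shows little about a phenyl with no substituents. Compound 1 also ends in plain phenyl and has a far higher number, but it differs from compound 3 elsewhere too, so that gap cannot be assigned to the phenyl alone. A moderate shift toward weaker inhibition is therefore expected, a 2.8-fold higher number from compound 3 to compound 4 (0.45 log units; beyond the scatter). In this assay, the estimate for compound 4 is 6000 nM, with an expected range from 2000 nM to 20000 nM.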

Compound 4, concentration for 50% growth inhibition: 41200 nM
Estimate against measurement, compound 4: 6.9-fold (0.84 log units) below; measured number above the stated range.
By their numbers in this assay, from the lowest: compounds 3 and 2 (each within the scatter of the next); then compounds 1 and 4 (each within the scatter of the next).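

At this position, para to a large group, the substituents on the end phenyl carry nearly all of the measured growth inhibition in this assay: replacing 3,4-dimethoxyphenyl with phenyl gives a 19-fold higher number from compound 3 to compound 4 (1.29 log units; beyond the scatter) and taking away dimethylamino gives a 19-fold higher number from compound 2 to compound 4 (1.27 log units; beyond the scatter) in a matching large move. Two different substituted phenyl groups therefore share a low number, while the plain phenyl does not, which the earlier step between the two substituted groups could not show. The new comparison with compound 1 gives a 1.3-fold higher number from compound 1 to compound 4 (0.11 log units; within the scatter) for the methyl on the shared core, so with a plain phenyl at the end this methyl leaves the number unchanged within the scatter, and the high number of compound 1 is matched by compound 4. No measurement shown here explains why the substituents on this ring matter so much.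

Still open, as far as these compounds go, is whether a single methoxy group, a hydroxyl or a fluorine on this ring would bring the number down as far as these larger substituents do. From the compounds shown here alone, it is also open whether the methyl on the core would remain without effect in the presence of 3,4-dimethoxyphenyl or 4-(dimethylamino)phenyl, or whether a carboxylic acid on the end ring would be tolerated.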